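Compound 3 to compound 4: a change of amine side chain

This account rests on a few compounds, and the source may have more. Where it says the series, first, only, none or still open, it means among the compounds named here.

In a functional assay on Fem-X cells (Homo sapiens) for cytotoxicity, read by MTT assay, with a stated time of 72 h (a lower number here means a stronger inhibitor, a higher number a weaker inhibitor), compound 3 `CC1=CCC[C@H]2[C@](C)(CC3=CC(=O)C=C(N[C@@H](CC(C)C)C(=O)O)C3=O)[C@@H](C)CC[C@]12C` gives 10900 nM as the lowest of the three measured numbers. Compound 2 `CC1=CCC[C@H]2[C@](C)(CC3=CC(=O)C=CC3=O)[C@@H](C)CC[C@]12C` gives 40300 nM on the same core without the amine side chain. Compound 1 `CC(C)(C)C1=CC(=O)C=C(NCC(=O)O)C1=O` stands on a different core and gives 34300 nM in this assay as well.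

The change to compound 4 `CC1=CCC[C@H]2[C@](C)(CC3=CC(=O)C=C(NCCC(=O)O)C3=O)[C@@H](C)CC[C@]12C` is 2-carboxyethyl in place of 1-carboxy-3-methylbutyl on an amine nitrogen and it leaves the shared core as it is: 2-carboxyethyl replaces 1-carboxy-3-methylbutyl on an amine nitrogen.

Going by the values given here, only one measured step bears on this change. It is a 3.7-fold lower number from compound 2 to compound 3 (0.57 log units; beyond the scatter) on installing the (1-carboxy-3-methylbutyl)amino group, a modest step beyond the scatter. Among the compounds with values here, no measured compound on this core carries the (2-carboxyethyl)amino group, so the effect of the swap itself is unknown. Compound 4 keeps an amine side chain with a carboxy group, so only a small rise is expected, not a full return to the number of compound 2. The expected step is a 1.7-fold higher number from compound 3 to compound 4 (0.22 log units; within the scatter) and would stay within the scatter. For compound 4 18000 nM is the estimated value, with 9000 nM to 36000 nM as the expected range.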

Compound 4, half-maximal inhibitory concentration: 20200 nM
Compound 4: the middle estimate sits 1.1-fold (0.05 log units) below what was measured; low and high end bracket the measured number.
By their numbers in this assay, from the lowest: compounds 3, 4, 1 and 2 (each within the scatter of the next, the first and the last beyond it).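

In this assay, 2-carboxyethyl in place of 1-carboxy-3-methylbutyl on the amine nitrogen gives a 1.9-fold higher number from compound 3 to compound 4 (0.27 log units; within the scatter), so this swap, which also removes a defined stereocentre, has no effect that can be told from the scatter. Setting (2-carboxyethyl)amino in place of hydrogen on the double-bonded ring carbon gives a 2.0-fold lower number from compound 2 to compound 4 (0.30 log units; within the scatter), whereas the (1-carboxy-3-methylbutyl)amino group gave a 3.7-fold lower number from compound 2 to compound 3 (0.57 log units; beyond the scatter), so compound 4 cannot be separated from either compound 2 or compound 3. No measurement at hand accounts for these numbers.

Still open, going by these compounds, is whether a longer chain such as 3-carboxypropyl on the amine nitrogen would separate from compound 3 in this assay. Also open, on these data alone, is what a methyl ester or primary amide in place of the carboxylic acid would do on the shared core.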